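Fluoro in Place of Chloro on the Benzyl Ring

This account rests on a few compounds, and the source may have more. Where it says the series, first, only, none or still open, it means among the compounds named here.

Compound 1 `C=C(Br)C(=O)Nc1cccc(/C=C2\SC(=O)N(Cc3ccc(Cl)cc3)C2=O)c1` — 1400 nM
Compound 2 `CC(C)(C)c1ccc(CN2C(=O)S/C(=C\c3ccc(N)cc3)C2=O)cc1` — 66000 nM

In a functional assay on CCRF-CEM cells (Homo sapiens) for cytotoxicity, read by cell counting, with a stated time of 3 days (on this read-out lower numbers stand for stronger inhibition and higher numbers for weaker inhibition), compound 1 gives 1400 nM, the lowest of the two numbers. Compound 2 gives 66000 nM, a gap beyond the scatter. Compound 3 `C=C(Br)C(=O)Nc1cccc(/C=C2\SC(=O)N(Cc3ccc(F)cc3)C2=O)c1` differs from compound 1 by fluoro in place of chloro on an aromatic carbon. Going by the values given here, no measured pair shows this change, so a shift no larger than the scatter is expected, if anything toward weaker inhibition. The expected step is a 1.3-fold higher number from compound 1 to compound 3 (0.11 log units; within the scatter). Compound 3 is estimated to give 1800 nM, with a range from 700 nM to 4500 nM.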

Compound 3, half-maximal inhibitory concentration: 680 nM
Compound 3: the middle estimate sits 2.6-fold (0.42 log units) above what was measured; the measured number lies below the stated range.
By their numbers in this assay, from the lowest: compound 3; then compound 1; then compound 2.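

In this assay, replacing 4-chlorobenzyl with 4-fluorobenzyl gives a 2.1-fold lower number from compound 1 to compound 3 (0.31 log units; beyond the scatter) and so shows that this position, on an aromatic carbon para to a large group, responds to the choice of halogen. The change runs toward stronger inhibition, and it is a single modest step on one core. Nothing available accounts for this shift.

As far as these compounds go, whether a bromo, a methoxy or a plain hydrogen at this place would continue the order remains open. So does whether the same swap would have a similar effect with a different group on the other aromatic ring.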